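The source may hold more compounds than are shown below. What is called first, only, known or untested is meant among the compounds shown, and "the series" means these compounds.

Compound 1 `C[C@@H](NC(=O)c1ccc(C#Cc2ccccc2)cn1)C(C)(C)O` — 43.2%
Compound 2 `C[C@@H](NC(=O)c1ccc(C#Cc2ccc(F)cc2F)cn1)C(C)(C)O` — 38.2%
Compound 3 `Cc1ccccc1C#Cc1ccc(C(=O)N[C@H](C)C(C)(C)O)nc1` — 24.1%

In an ADME assay on HEK293 cells for agonist activity at metabotropic glutamate receptor 5 (Rattus norvegicus), read by fluorescence and calcium flux (a lower number here means a smaller maximal response, a higher number a larger maximal response), compound 3 stands lowest of the three measured compounds, with a number 19.1 percentage points lower from compound 1 to compound 3 (beyond the scatter) and a number 14.1 percentage points lower from compound 2 to compound 3 (beyond the scatter). Compound 4 `C[C@@H](NC(=O)c1ccc(C#Cc2cccnc2)cn1)C(C)(C)O` has not yet been measured. Its change from compound 3 is pyridin-3-yl in place of 2-methylphenyl on a triple-bonded carbon. Among the measured compounds shown here, no measured step matches this exactly; the step of a number 5 percentage points lower from compound 1 to compound 2 (within the scatter) shows that a change on the ring at the triple-bonded carbon need not move the response, whereas the two steps into compound 3 show that the 2-methylphenyl lowers it modestly. Since the methyl leaves, the response of compound 4 is expected to move back up toward the numbers of compounds 1 and 2. The step expected for compound 4 is a number 13.9 percentage points higher from compound 3 to compound 4 (beyond the scatter). The estimate for compound 4 is 38%, between 22% and 54%.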

Compound 4, largest response reached (reported as efficacy), in percent of the reference or control that the assay uses: 25.9%
The estimate for compound 4 lay 12.1 percentage points above the measured number, within the range that was stated.
By their numbers in this assay, from the lowest: compounds 3 and 4 (each within the scatter of the next); then compounds 2 and 1 (each within the scatter of the next).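

In this assay the change on the triple-bonded carbon gives a number 1.8 percentage points higher from compound 3 to compound 4 (within the scatter) and so shows that a low response at this place does not depend on the 2-methylphenyl. Pyridin-3-yl also gives a number 17.3 percentage points lower from compound 1 to compound 4 (beyond the scatter) and a number 12.3 percentage points lower from compound 2 to compound 4 (beyond the scatter) and thus shows that this place responds to more than the methyl: a ring with one hetero atom stands apart from both phenyl and 2,4-difluorophenyl. No measurement offered here explains this result.

The compounds shown leave open how pyridin-4-yl or pyridin-2-yl would read on this triple-bonded carbon, and how a phenyl ring carrying an amine or a methoxy group would compare.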